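Bulkier acrylamide tail on a shared kinase-inhibitor core

The source may hold more compounds than are shown below. What is called first, only, known or untested is meant among the compounds shown, and "the series" means these compounds.

Two measured compounds set the scene. Compound 1, `COc1cc(N(C)CCN(C)C)c(NC(=O)C=C(C)C)cc1Nc1nccc(-c2cn(C)c3ccccc23)n1`, gives 5610 nM in a functional assay on NCI-H1975 cells (Homo sapiens) for antiproliferative activity, read by MTT assay, with a stated time of 72 h; a lower number here means a stronger inhibitor, a higher number a weaker inhibitor. Compound 2, `C=CC(=O)Nc1cc(Nc2nc(C)cc(-c3cn(C)c4ccccc34)n2)c(OC)cc1N(C)CCN(C)C`, gives 4810 nM in this assay. Going by the values given here, these two numbers lie within the usual scatter of each other, so neither compound can be called the stronger inhibitor, and the two structures differ in more than one place, so no single step joins them.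

Compound 3, `COc1cc(N(C)CCN(C)C)c(NC(=O)/C=C\C(C)C)cc1Nc1nc(C)cc(-c2cn(C)c3ccccc23)n1`, is not yet measured. It differs from compound 2 in one place: 3-methylbut-1-en-1-yl in place of vinyl on a carbonyl carbon. The amide-bearing end of the molecule thus carries a longer branched chain where compound 2 has the short vinyl group.

Among the compounds with values here, no measured pair shows what this kind of change does here. Within the data shown here, the only hint is that compound 1, which also carries a substituted rather than a bare vinyl on its carbonyl, sits close to compound 2 in this assay. A small step toward a weaker inhibitor is expected for compound 3, a 1.7-fold higher number from compound 2 to compound 3 (0.22 log units; within the scatter), not clearly beyond the scatter. Compound 3 is therefore estimated at 8000 nM in this assay, within a range from 3500 nM to 20000 nM.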

Compound 3, half-maximal inhibitory concentration: 1230 nM
Compound 3: middle estimate off by 6.5-fold (0.81 log units), on the high side; measured number below the stated range.
By their numbers in this assay, from the lowest: compound 3; then compounds 2 and 1 (each within the scatter of the next).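

In this assay, putting 3-methylbut-1-en-1-yl in place of vinyl on a carbonyl carbon gives a 3.9-fold lower number from compound 2 to compound 3 (0.59 log units; beyond the scatter), a step beyond the usual scatter. Going by these compounds alone, this is the first change in this set that can be read in one place, and it shows that this carbonyl carbon can carry a chain of 5 carbon atoms instead of 2 without any loss in this assay; the number in fact falls, towards a stronger inhibitor. Nothing available explains why the longer branched chain goes with the lower number, so the step stands as an observation only.

One step cannot show whether size, branching or some other feature of the chain matters, nor whether the same swap would have a similar effect on a different core. From the compounds shown here alone, it also remains open how other groups on this carbonyl carbon would compare with 3-methylbut-1-en-1-yl, such as a longer unbranched chain, a chain ending in a dimethylamine, or a phenyl ring.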